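This account rests on a few compounds, and the source may have more. Where it says the series, first, only, none or still open, it means among the compounds named here.

Measured so far:
- compound 1, `Cc1oncc1NS(=O)(=O)c1ccc(F)c2ncc(I)cc12`: 2100 nM
- compound 2, `CCCCCOS(=O)(=O)c1ccc(F)c2ncc(I)cc12`: > 200000 nM
- compound 3, `O=S(=O)(c1ccc(F)c2ncc(I)cc12)N1CCCC1`: > 200000 nM

In an assay for inhibition of methylcytosine dioxygenase TET2 (Homo sapiens), read by mass spectrometry, with stated times of 30 min and 1 h (on this read-out higher numbers stand for weaker inhibition and lower numbers for stronger inhibition), compound 1 gives 2100 nM. Among the measured compounds shown here, it is the only compound of the three with a real number. For compound 2 the result is a limit of the assay, > 200000 nM. For compound 3 the result is likewise a limit, > 200000 nM. Both sit at the limit of > 200000 nM in this assay, at which 2 of the 3 values shown sit.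

Compound 4, `O=S(=O)(NC1CCCCC1)c1ccc(F)c2ncc(I)cc12`, differs from compound 1 in one place: cyclohexyl in place of 5-methyl-1,2-oxazol-4-yl on a sulfonamide nitrogen. The sulfonamide nitrogen with its hydrogen stays, but the aromatic ring on it gives way to a saturated carbon ring.

For the measured compounds named here, two measured steps bear on this. Replacing the same five-membered aromatic ring on the sulfonyl sulfur gave an at least 95-fold higher number from compound 1 to compound 2 (1.97 log units; beyond the scatter) and an at least 95-fold higher number from compound 1 to compound 3 (1.97 log units; beyond the scatter). Both changes removed the ring entirely and also removed the sulfonamide hydrogen, so they are not the same change as in compound 4, but they point the same way: away from that ring, the numbers in this assay rise sharply. For compound 4 a clearly higher number than for compound 1 is therefore expected, a 19-fold higher number from compound 1 to compound 4 (1.28 log units; beyond the scatter), with a fair chance that only a limit is reported. The estimate for compound 4 in this assay is 40000 nM, ranging from 6000 nM to 200000 nM.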

Compound 4, half-maximal inhibitory concentration: > 200000 nM
Compound 4 ended at the assay's limit (the forecaster's own chance of this, stated with the estimate: 35%); at least 5.0-fold (0.69 log units) between middle value and limit.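

Compounds 2 and 3 lost the aromatic ring and the sulfonamide hydrogen together, so they could not show which loss mattered. Compound 4 keeps that hydrogen and changes only the group on the sulfonamide nitrogen, yet in this assay cyclohexyl in place of 5-methyl-1,2-oxazol-4-yl gives an at least 95-fold higher number from compound 1 to compound 4 (1.97 log units; beyond the scatter), so among these compounds the hydrogen alone does not preserve a measurable inhibition. Compounds 2, 3 and 4 cannot be ranked against one another, and the steps between them cannot be read, because of where their results sit: the limit of > 200000 nM in this assay, at which 3 of the 4 values shown sit.

Still open, on these data alone, is whether the aromatic character of the 5-methyl-1,2-oxazol-4-yl ring counts, or its nitrogen and oxygen atoms. A phenyl group on the sulfonamide nitrogen would help separate these two, and an unsubstituted 1,2-oxazol-4-yl group would test the part played by the methyl.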